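The source may hold more compounds than are shown below. What is called first, only, known or untested is meant among the compounds shown, and "the series" means these compounds.

Compound 1 `CCOC(=O)/C=C/c1ccc(NC(=O)C2(NC(=O)c3ccc4c(C5CCCC5)c(-c5ncc(Cl)cn5)n(C)c4c3)CCC2)cc1OCC` reaches the limit of an ADME assay (liver) for pharmacokinetics, with Liver microsome (Homo sapiens) as the target, using microsomes (on this read-out higher numbers stand for a longer-lived compound and lower numbers for a shorter-lived compound), at > 5 h.
Compound 2 `CCOc1cc(NC(=O)C2(NC(=O)c3ccc4c(C5CCCC5)c(-c5ncc(Cl)cn5)n(C)c4c3)CCC2)ccc1/C=C/C(=O)OCC(C)C` likewise sits at the limit of this assay, giving > 5 h.

Because both values are limits rather than numbers, the step that the two limits leave unreadable from compound 1 to compound 2 cannot be read, and the limit of > 5 h in this assay, at which 2 of the 2 values shown sit, is all that the two measurements show. Compound 2 therefore stands at a limit, not at a measured number. Compound 3 `CCCCCCOC(=O)/C=C/c1ccc(NC(=O)C2(NC(=O)c3ccc4c(C5CCCC5)c(-c5ncc(Cl)cn5)n(C)c4c3)CCC2)cc1OCC` differs from compound 2 by pentyl in place of isopropyl on a saturated chain carbon bound to an oxygen next to a carbonyl group. Among the compounds with values here, no measured step bears on this change. The step that the limit leaves unreadable from compound 2 to compound 3 is expected to stay within the scatter. Compound 3 is estimated at 6 h, within a range from 3.5 h to 12 h, most likely again reported as a limit.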

Compound 3, half-life: 17.9 h
Estimate against measurement, compound 3: 3.0-fold (0.47 log units) below; the whole stated range lies below it.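

Within the data shown here, no step from compound 1 or compound 2 to compound 3 can be read, as the values of compound 1 and compound 2 are limits, not numbers: the limit of > 5 h in this assay, at which 2 of the 3 values shown sit. The compounds shown leave open whether pentyl in place of isopropyl changes the half-life in this assay at all.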